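Swapping methyl for 1-hydroxyethyl on the side chain

The compounds below may be only part of what the source reports. "The series", "measured", "known", "first", "only" and "open" are said of these compounds alone.

In an ADME assay on FSCLL cells (Homo sapiens) for cytotoxicity, read by MTT assay, with a stated time of 24 h (a higher number here means that more compound is tolerated, a lower number that less compound is tolerated), compound 1 `CNCC(=O)N[C@@H](CC(C)C)B(O)O` gives 160 nM, while compound 2 `CC(C)C[C@H](NC(=O)[C@@H](N)CO)B(O)O` gives 1700 nM and compound 3 `CC(C)C[C@H](NC(=O)[C@H](C)N)B(O)O` gives 3200 nM on the same scale. Compound 3 shares the upper end of these numbers with compound 2, and the lower end belongs to compound 1 alone: the steps of an 11-fold higher number from compound 1 to compound 2 (1.03 log units; beyond the scatter) and a 20-fold higher number from compound 1 to compound 3 (1.30 log units; beyond the scatter) are both large. Compound 4 `CC(C)C[C@H](NC(=O)[C@@H](N)[C@@H](C)O)B(O)O` has 1-hydroxyethyl in place of methyl on a saturated chain carbon bound to an amine nitrogen and a carbonyl carbon. Those large steps replace (methylamino)methyl, which is not the group changing here, so they offer little guidance. The nearest guide is the swap of hydroxy for hydrogen, where a 1.9-fold higher number from compound 2 to compound 3 (0.27 log units; within the scatter) stays small. No shift beyond the scatter is therefore expected, and the estimated change is a 1.3-fold lower number from compound 3 to compound 4 (0.11 log units; within the scatter) in this assay at most a slight drop in the number. Compound 4 is estimated at 2500 nM (expected range 900 nM to 7000 nM).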

Compound 4, half-maximal cytotoxic concentration: 2500 nM
Compound 4: the middle estimate sits on the measured number at the digits printed; the range from low to high includes it.
By their numbers in this assay, from the lowest: compound 1; then compounds 2, 4 and 3 (each within the scatter of the next).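

In this assay, putting 1-hydroxyethyl in place of methyl on a saturated chain carbon bound to an amine nitrogen and a carbonyl carbon gives a 1.3-fold lower number from compound 3 to compound 4 (0.11 log units; within the scatter) and so shows that this position takes the larger group with no shift beyond the scatter. The extra methyl on the hydroxy-bearing side chain gives a 1.5-fold higher number from compound 2 to compound 4 (0.17 log units; within the scatter) and leaves compound 2, compound 3 and compound 4 as a group that this assay does not separate. Among the compounds shown here, the one large step remains the one that involves (methylamino)methyl, with a 16-fold higher number from compound 1 to compound 4 (1.19 log units; beyond the scatter) when 1-amino-2-hydroxypropyl takes its place.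

Still open, from the compounds shown here alone, is whether a longer chain, a carboxylic acid or a phenyl ring on this carbon would stay within the same narrow band. No measurement shown here gives a reason for how closely these side chains agree.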